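This account rests on a few compounds, and the source may have more. Where it says the series, first, only, none or still open, it means among the compounds named here.

Compound 1, `O=C(CCCCCc1ccc(O)c(Cl)c1)N1CCOC1=O`, gives in an assay on HEK293 cells for inhibition of N-acylethanolamine-hydrolyzing acid amidase (Rattus norvegicus), read by LC-MS, with a stated time of 30 min (a lower number here means a stronger inhibitor, a higher number a weaker inhibitor), only a limit, > 20000 nM.
Compound 2, `NC(=O)c1cccc(CCCCCC(=O)N2CCOC2=O)c1`, likewise gives only a limit, > 20000 nM.
Compound 3, `O=C1OCCN1C(=O)c1ccc(Oc2ccccc2)cc1`, gives 680 nM.

Compound 3 is thus the only one of the three with a number in this assay; the other two values sit at a limit (the limit of > 20000 nM in this assay, at which 2 of the 3 values shown sit). For the measured compounds named here, no pair of measured compounds differing in a single place is available, so no measured step can guide the next change. Compound 4, `O=C1OCCN1C(=O)c1ccc(OC2CCCC2)cc1`, differs from compound 3 by cyclopentyl in place of phenyl on an oxygen on an aromatic ring. In this assay the step from compound 3 is expected to be modest and, if anything, toward weaker inhibition, though a value within the usual scatter is also plausible. Compound 4 is expected to give about 1500 nM, with a likely range from 400 nM to 6000 nM. The expected step is a 2.2-fold higher number from compound 3 to compound 4 (0.34 log units; beyond the scatter).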

Compound 4, half-maximal inhibitory concentration: 120 nM
Compound 4: the middle estimate sits 13-fold (1.10 log units) above what was measured; measured number below the stated range.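

Cyclopentyl in place of phenyl on an oxygen on an aromatic ring gives a 5.7-fold lower number from compound 3 to compound 4 (0.75 log units; beyond the scatter) in this assay. For the compounds shown here, this is the only measured single-place step here, and it shows that a phenyl ring at this place is not required for inhibition, since a non-aromatic ring of carbon only gives the lower number. Nothing shown here accounts for the size of this step. The compounds shown leave open whether the gain is particular to cyclopentyl or extends to cyclohexyl or an open butyl chain on the same oxygen.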